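Aryl replacement of the alkyne on a C-nucleoside core

A few compounds are considered here, and "the series" means these few. Any claim that something is new, unique, unknown or untested is made for them only; others in the source may bear on it.

Measured so far in a functional assay on K562 cells (Homo sapiens) for antiproliferative activity, with a stated time of 72 h; a higher number here means a weaker inhibitor, a lower number a stronger inhibitor:
- compound 1 `CCCC#Cc1cc([C@@H]2O[C@H](CO)[C@@H](O)[C@H]2O)n2ncnc(N)c12`: compound 1 gives 1100 nM.
- compound 2 `Nc1ncnn2c([C@@H]3O[C@H](CO)[C@@H](O)[C@H]3O)cc(-c3ccccc3)c12`: compound 2 gives only a limit, > 100000 nM.
- compound 3 `Nc1ncnn2c([C@@H]3O[C@H](CO)[C@@H](O)[C@H]3O)cc(-c3ccc(F)cc3)c12`: compound 3 gives only a limit, > 100000 nM.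

Compound 3 stands at the limit of this assay, not at a number. The two steps that lead to an aryl group on the same aromatic carbon are both large: an at least 90-fold higher number from compound 1 to compound 2 (1.95 log units; beyond the scatter) and an at least 90-fold higher number from compound 1 to compound 3 (1.95 log units; beyond the scatter). Between the two aryl compounds the step that the two limits leave unreadable from compound 2 to compound 3 cannot be read, as both sit at the limit described by the limit of > 100000 nM in this assay, at which 2 of the 3 values shown sit.

Compound 4 `Nc1ncnn2c([C@@H]3O[C@H](CO)[C@@H](O)[C@H]3O)cc(-c3ccccc3F)c12` differs from compound 3 by 2-fluorophenyl in place of 4-fluorophenyl on an aromatic carbon. Within the data shown here, both measured aryl steps point the same way, and the move of fluorine within the ring has no measured precedent here beyond the unreadable step. Compound 4 is therefore expected to stay at or near the limit of this assay, with the expected step of a number no higher from compound 3 to compound 4 (the limit leaves the size open) not readable beyond the scatter. The estimate for compound 4 is 100000 nM, in the range 20000 nM to 400000 nM.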

Compound 4, half-maximal inhibitory concentration: > 100000 nM
Compound 4 was reported as a limit; the forecaster's own chance of this, stated with the estimate: 75%; the middle value sits exactly at the limit.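

In this assay, the 2-fluorophenyl group extends the large loss seen with phenyl and 4-fluorophenyl in place of pent-1-yn-1-yl on this aromatic carbon, with an at least 90-fold higher number from compound 1 to compound 4 (1.95 log units; beyond the scatter). Compound 4 gives only a limit, > 100000 nM, so moving the fluorine from the 4-fluorophenyl to the 2-fluorophenyl arrangement brings no measurable antiproliferative value back. The steps among compound 2, compound 3 and compound 4 cannot be read, and all three compounds share one limit: the limit of > 100000 nM in this assay, at which 3 of the 4 values shown sit.

Any ordering among these aryl groups remains hidden behind that limit. On these data alone, it also remains open whether a pentyl chain, a shorter alkynyl chain such as prop-1-yn-1-yl, or an amine on this aromatic carbon would give a measurable value in this assay.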